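Methoxy for methylamino on the shared core of compound 2

A few compounds are considered here, and "the series" means these few. Any claim that something is new, unique, unknown or untested is made for them only; others in the source may bear on it.

In a functional assay on HeLa S3 cells (Homo sapiens) for antiproliferative activity, read by XTT assay, with a stated time of 72 h (on this read-out lower numbers stand for stronger inhibition and higher numbers for weaker inhibition), compound 2 `CNc1ncnc2c1c(-c1ccco1)cn2[C@@H]1O[C@H](CO)[C@@H](O)[C@H]1O` gives 5000 nM, the highest of the two numbers at hand; compound 1 `COc1ncnc2c1c(-c1ccoc1)cn2[C@@H]1O[C@H](CO)[C@@H](O)[C@H]1O` gives 1790 nM, a gap beyond the usual scatter. Compound 3 `COc1ncnc2c1c(-c1ccco1)cn2[C@@H]1O[C@H](CO)[C@@H](O)[C@H]1O` has not yet been measured. It differs from compound 2 by methoxy in place of methylamino on an aromatic carbon. Going by the values given here, no directly comparable step is available, but compound 1 also carries methoxy and its 1790 nM sits below compound 2. A modest step toward a lower number is therefore expected from compound 2 to compound 3, a 2.0-fold lower number from compound 2 to compound 3 (0.30 log units; within the scatter). For compound 3 in this assay the estimate is 2500 nM, with a range from 900 nM to 7000 nM.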

Compound 3, half-maximal inhibitory concentration: 1020 nM
Beside the measured number, compound 3's estimate is 2.5-fold (0.39 log units) above it; the range from low to high includes it.
By their numbers in this assay, from the lowest: compounds 3 and 1 (each within the scatter of the next); then compound 2.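

In this assay methoxy in place of methylamino on the aromatic carbon next to the ring nitrogen now has a matched reading: a 4.9-fold lower number from compound 2 to compound 3 (0.69 log units; beyond the scatter) lies beyond the scatter. By contrast, furan-2-yl in place of furan-3-yl gives a 1.8-fold lower number from compound 1 to compound 3 (0.24 log units; within the scatter) and stays within the scatter, so this furan change does not separate the two compounds. Nothing measured here gives a reason for either step. The compounds shown leave open how ethoxy, dimethylamino or a primary amine would read at this position, and whether the methoxy step holds with furan-3-yl on the shared core.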